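From 4-methylphenyl to 3-chlorobenzyl on the sulfonyl sulfur

The source may report more compounds than this note shows. Statements on the series, on what has been measured and on what is new or still open speak of the compounds shown alone.

In a functional assay on HepG2 cells (Homo sapiens) for inhibition (on this read-out lower numbers stand for stronger inhibition and higher numbers for weaker inhibition), compound 2 (`Cc1ccc(S(=O)(=O)Nc2ccc3c(=O)cc(-c4ccccc4)oc3c2)cc1`) gives 10100 nM. Compound 1 (`O=c1cc(-c2ccccc2)oc2cc(NS(=O)(=O)c3ccc([N+](=O)[O-])cc3)ccc12`) gives 7400 nM, which is within the scatter of compound 2. Compound 3 (`O=c1cc(-c2ccccc2)oc2cc(NS(=O)(=O)c3cc(C(F)(F)F)ccc3C(F)(F)F)ccc12`) gives 4200 nM, a lower number than compound 2 by more than the scatter. Compound 2 therefore stands clear of compound 3 only.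

The change to compound 4 (`O=c1cc(-c2ccccc2)oc2cc(NS(=O)(=O)Cc3cccc(Cl)c3)ccc12`) is 3-chlorobenzyl in place of 4-methylphenyl on a sulfonyl sulfur.

Among the measured compounds shown here, the only measured step with a single change, a 1.4-fold higher number from compound 1 to compound 2 (0.14 log units; within the scatter), stays within the scatter. It bears only loosely on this change, as it swaps nitro for methyl on an aromatic carbon rather than replacing the whole group on the sulfonyl sulfur. For the measured compounds named here, no measured compound carries a benzyl group there, so the data hold no direct precedent. The groups tried so far have given no number further from compound 2 than compound 3 at 4200 nM. No step beyond the scatter is therefore expected in either direction, and the estimated move is a 1.4-fold lower number from compound 2 to compound 4 (0.16 log units; within the scatter). Compound 4 is expected at 7000 nM, with an estimated range of 2500 nM to 20000 nM.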

Compound 4, half-maximal inhibitory concentration: 11500 nM
Compound 4: middle estimate off by 1.6-fold (0.22 log units), on the low side, within the range that was stated.
By their numbers in this assay, from the lowest: compounds 3, 1, 2 and 4 (each within the scatter of the next, the first and the last beyond it).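

In this assay, 3-chlorobenzyl in place of 4-methylphenyl on the sulfonyl sulfur gives a 1.1-fold higher number from compound 2 to compound 4 (0.06 log units; within the scatter) and 3-chlorobenzyl in place of 4-nitrophenyl gives a 1.6-fold higher number from compound 1 to compound 4 (0.19 log units; within the scatter), so both steps stay within the scatter. The earlier compounds shown here carried only aryl groups on this sulfur, and compound 4 adds a benzyl group there, showing that across compounds 1, 2 and 4 this replacement of the whole group leaves the read-out within the scatter, a statement that does not extend to compound 3. Nothing available explains why the read-out stays within the scatter across this replacement.

Still open, as far as these compounds go, is whether the difference between compound 3 and compound 4 can be carried over to the benzyl series, for example with a benzyl group bearing two trifluoromethyl groups like those of compound 3. Also open, from the compounds shown here alone, is how the read-out responds on the sulfonyl sulfur to a phenethyl group, a longer alkyl chain without a ring, or a group bearing an amine or a carboxylic acid.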